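The source may hold more compounds than are shown below. What is called first, only, known or untested is meant among the compounds shown, and "the series" means these compounds.

Working notes on the series.

Among the compounds with values here, compound 3 `Cc1ccc(C#Cc2ccc(S(=O)(=O)N[C@@H](C(=O)O)C(C)C)s2)cc1` gives 24 nM in an assay on isolated protein for inhibition of matrix metalloproteinase-9 (Homo sapiens) (on this read-out lower numbers stand for stronger inhibition and higher numbers for weaker inhibition), the lowest of the three numbers so far. Compound 1 `CC(C)[C@@H](NS(=O)(=O)c1ccc(-c2nnn(-c3ccccc3)n2)cc1)C(=O)O` gives 72 nM in this assay, and compound 2 `CC(C)[C@H](C(=O)O)N(C)S(=O)(=O)c1ccc(-c2nnn(-c3ccccc3)n2)cc1` gives 870 nM. Within the data shown here, the one single-point step among the measured compounds, a 12-fold higher number from compound 1 to compound 2 (1.08 log units; beyond the scatter), concerns a methyl in place of hydrogen on the sulfonamide nitrogen; it is large and points toward weaker inhibition.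

Compound 4 `CC(C)[C@@H](NS(=O)(=O)c1ccc(C#Cc2ccc(Oc3ccccc3)cc2)s1)C(=O)O` is not yet measured. It differs from compound 3 in one place: phenoxy in place of methyl on an aromatic carbon. Among the measured compounds shown here, the sulfonamide nitrogen, where the only measured step acts, stays untouched between compound 3 and compound 4, so that step does not bear on this change. For the measured compounds named here, no measured pair shows what replacing the methyl with phenoxy on this aromatic carbon does, and the expectation therefore rests on compound 3 alone, with a wide range around it.

The step from compound 3 to compound 4 in this assay is expected to be a 1.2-fold lower number from compound 3 to compound 4 (0.08 log units; within the scatter), that is, no clear move beyond the scatter in either direction. Compound 4 is estimated to give about 20 nM in this assay, somewhere between 6 nM and 70 nM.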

Compound 4, half-maximal inhibitory concentration: 260 nM
The estimate for compound 4 lay 13-fold (1.11 log units) below the measured number; the measured number lies above the stated range.
By their numbers in this assay, from the lowest: compound 3; then compound 1; then compound 4; then compound 2.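

The aromatic carbon para to a large group is not indifferent to what it carries: phenoxy in place of methyl gives an 11-fold higher number from compound 3 to compound 4 (1.03 log units; beyond the scatter) in this assay, so the group entering here, with its seven heavy atoms and one six-membered aromatic ring, is not accommodated without a large loss. Until now the sulfonamide nitrogen was the only place with a measured step, and this second place moves the number in the same direction, toward weaker inhibition, with a step of similar size to a 12-fold higher number from compound 1 to compound 2 (1.08 log units; beyond the scatter) on that nitrogen. No measurement on these compounds speaks to what lies behind the new step, which stands as an observation only.

On these data alone, with only methyl and phenoxy seen on this carbon, it remains open whether the rise in the number goes with the ring or with the ether oxygen, and a plain phenyl, a methoxy or a benzyl group here would separate these. Also open, as far as these compounds go, is whether an amine or a carboxylic acid at this carbon would behave like methyl, like phenoxy or like neither.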